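The compounds below may be only part of what the source reports. "The series", "measured", "known", "first", "only" and "open" are said of these compounds alone.

Measured compounds:
- compound 1, `c1ccc2c(-c3cn4ccnc4c(-c4ccc5ncn(C6CCCCC6)c5c4)n3)cccc2c1`: 4.46%
- compound 2, `Fc1ccc(-c2cn3ccnc3c(-c3ccc4ncn(C5CCCCC5)c4c3)n2)cc1`: 7.59%
- compound 3, `Clc1ccc(-c2cn3ccnc3c(-c3ccc4ncn(C5CCCCC5)c4c3)n2)cc1`: 15.5%

All three share one core and differ only in the aromatic group attached to it. In a functional assay on HCT-15 cells (Homo sapiens) for inhibition, read by sulforhodamine B assay, with a stated time of 48 h, tested at 10 uM (a lower number here means less inhibition, a higher number more inhibition at the concentration tested (going by the name of the read-out)), compound 3 gives the highest of the three numbers, yet only its gap to compound 1 is beyond the scatter; the step of a number 11 percentage points higher from compound 1 to compound 3 (beyond the scatter) is modest, while a number 7.9 percentage points higher from compound 2 to compound 3 (within the scatter) and a number 3.1 percentage points higher from compound 1 to compound 2 (within the scatter) stay within the scatter. The numbers therefore say little more than that changing this aromatic group shifts inhibition by small amounts.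

Compound 4, `COc1ccccc1-c1cn2ccnc2c(-c2ccc3ncn(C4CCCCC4)c3c2)n1`, is not yet measured. It differs from compound 3 in one place: 2-methoxyphenyl in place of 4-chlorophenyl on an aromatic carbon. The two steps that bear on this position are a number 11 percentage points higher from compound 1 to compound 3 (beyond the scatter) and a number 7.9 percentage points higher from compound 2 to compound 3 (within the scatter), both small. A change of a similar size is expected, most likely downward, since compound 3 already stands at the top of a narrow spread. The expected step is a number 5.5 percentage points lower from compound 3 to compound 4 (within the scatter), and compound 4 is estimated to give 10% in this assay, within a range from 0% to 25%.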

Compound 4, a percentage reported as inhibition, at one concentration (the size of the read-out at that concentration, not a potency): 33.6%
For compound 4 the middle estimate is 23.6 percentage points below the measured one; measured number outside the range, above it.
By their numbers in this assay, from the lowest: compounds 1, 2 and 3 (each within the scatter of the next, the first and the last beyond it); then compound 4.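

In this assay, 2-methoxyphenyl brings a number 18.1 percentage points higher from compound 3 to compound 4 (beyond the scatter) and a number 26 percentage points higher from compound 2 to compound 4 (beyond the scatter) and also a number 29.1 percentage points higher from compound 1 to compound 4 (beyond the scatter) as the steps of this one change. The aromatic group on this carbon can therefore move the number further than the swaps among naphthalen-1-yl, 4-fluorophenyl and 4-chlorophenyl suggested, and compound 4 stands clear of all three compounds. No measurement here accounts for this rise.

The change replaces the substituent and also moves it around the phenyl ring, so the compounds shown cannot say whether the methoxy group itself or its location matters more; 4-methoxyphenyl and 2-chlorophenyl would separate the two. Going by these compounds, whether other groups at the same spot on the phenyl ring, such as an amine or a carboxylic acid, go further also remains open.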